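The compounds below may be only part of what the source reports. "The series", "measured", "known", "first", "only" and "open" are said of these compounds alone.

Of the compounds shown here, three built on one shared core have so far been measured in a functional assay on SK-MEL-5 cells (Homo sapiens) for inhibition, read by sulforhodamine B assay, with a stated time of 48 h; a lower number here means that less compound is tolerated, a higher number that more compound is tolerated. Compound 1 `COc1cc(-c2nn(-c3cccc(NC(=O)c4cccc(C(F)(F)F)c4)c3)cc2-c2ccncc2)ccc1Cl` gives 40600 nM in this assay. Compound 2 `COc1cc(-c2nn(-c3cccc(NC(=O)Nc4ccc(Cl)c(Cl)c4)c3)cc2-c2ccncc2)ccc1Cl` gives 3020 nM. Compound 3 `COc1cc(-c2nn(-c3cccc(NC(=O)c4ccc(Cl)c(C(F)(F)F)c4)c3)cc2-c2ccncc2)ccc1Cl` gives 31800 nM, which places it second highest of the three numbers; its nearest neighbour is compound 1, and the step of a 1.3-fold lower number from compound 1 to compound 3 (0.11 log units; within the scatter) lies within the scatter, whereas the step of an 11-fold higher number from compound 2 to compound 3 (1.02 log units; beyond the scatter) is large.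

Compound 4 `COc1cc(-c2nn(-c3cccc(NC(=O)Nc4ccc(Cl)c(C(F)(F)F)c4)c3)cc2-c2ccncc2)ccc1Cl` has not yet been measured. It differs from compound 3 in one place: (4-chloro-3-(trifluoromethyl)phenyl)amino in place of 4-chloro-3-(trifluoromethyl)phenyl on a carbonyl carbon. Within the data shown here, two measured steps bear on this change. The step of a 13-fold lower number from compound 1 to compound 2 (1.13 log units; beyond the scatter) paired the same kind of exchange on the carbonyl carbon with a change of the aromatic substituents, and the step of an 11-fold higher number from compound 2 to compound 3 (1.02 log units; beyond the scatter) ran the exchange the other way, again with different substituents. The step of a 1.3-fold lower number from compound 1 to compound 3 (0.11 log units; within the scatter) shows that chloro on the aromatic ring by itself leaves the number within the scatter. A large downward step in this assay is therefore expected for compound 4, about an 11-fold lower number from compound 3 to compound 4 (1.03 log units; beyond the scatter). The estimated value for compound 4 is 3000 nM, with a range from 1000 nM to 9000 nM.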

Compound 4, concentration lethal to 50% of the cells: 10400 nM
Compound 4: middle estimate off by 3.5-fold (0.54 log units), on the low side; measured number outside the range, above it.
By their numbers in this assay, from the lowest: compound 2; then compound 4; then compounds 3 and 1 (each within the scatter of the next).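

In this assay, the amino exchange on the carbonyl carbon can now be read with the aromatic substituents held the same, and it gives a 3.1-fold lower number from compound 3 to compound 4 (0.49 log units; beyond the scatter), a modest step, whereas the large steps of a 13-fold lower number from compound 1 to compound 2 (1.13 log units; beyond the scatter) and an 11-fold higher number from compound 2 to compound 3 (1.02 log units; beyond the scatter) each carried a change of aromatic substituents as well. Those substituents therefore also count once the amino group is present: trifluoromethyl in place of chloro gives a 3.4-fold higher number from compound 2 to compound 4 (0.54 log units; beyond the scatter), so the large earlier steps cannot be credited to the amino exchange alone, and the combined change gives a 3.9-fold lower number from compound 1 to compound 4 (0.59 log units; beyond the scatter). Nothing given here explains why either change moves the number as it does.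

The amino exchange is read cleanly in only one pair, so the compounds shown leave open whether a step of this size would recur with other groups on the aromatic ring, such as a nitrile in place of trifluoromethyl. They also leave open what a methyl on the nitrogen attached to the carbonyl carbon would do to the number.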